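The source may hold more compounds than are shown below. What is called first, only, known or untested is meant among the compounds shown, and "the series" means these compounds.

In a functional assay on MC-38 cells (Mus musculus) for antiproliferative activity (on this read-out higher numbers stand for weaker inhibition and lower numbers for stronger inhibition), compound 1 (`N#Cc1c[nH]c2c(NS(=O)(=O)c3ccc(N)cc3)cccc12`) gives 0.28 ug/mL and compound 2 (`NC(=O)c1ccc(S(=O)(=O)Nc2cccc3c(Cl)c[nH]c23)cc1`) gives 0.19 ug/mL, two values within the usual scatter of each other. Compound 3 (`Nc1ccc(S(=O)(=O)Nc2cccc3c(Cl)c[nH]c23)cc1`) differs from compound 2 in one place: amino in place of carbamoyl on an aromatic carbon, with amino in place of carbamoyl on an aromatic carbon, para to a large group. Compound 1 also carries amino and gives 0.28 ug/mL, so no change beyond the scatter is expected in this assay. The estimated step of a 1.1-fold higher number from compound 2 to compound 3 (0.02 log units; within the scatter) stays within that scatter. Compound 3 is expected at 0.2 ug/mL, with an estimated range of 0.08 ug/mL to 0.5 ug/mL.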

Compound 3, half-maximal inhibitory concentration: 0.23 ug/mL
Beside the measured number, compound 3's estimate is 1.2-fold (0.06 log units) below it; the measured number falls inside the stated range.
By their numbers in this assay, from the lowest: compounds 2, 3 and 1 (each within the scatter of the next).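

In this assay amino in place of carbamoyl on an aromatic carbon, para to a large group, gives a 1.2-fold higher number from compound 2 to compound 3 (0.08 log units; within the scatter) and so this position accepts either group without a change beyond the scatter. Chloro in place of cyano on an aromatic carbon gives a 1.2-fold lower number from compound 1 to compound 3 (0.09 log units; within the scatter) and so this second change also leaves the number within the scatter. Nothing available gives a reason for either result. On these data alone, whether a carboxylic acid or a dimethylamino group at the para position would keep the number in this range remains open, as does whether a bromo group would do so in place of chloro.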